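This account rests on a few compounds, and the source may have more. Where it says the series, first, only, none or still open, it means among the compounds named here.

Three measured members of the series share one core and differ only in the aromatic group attached to the carbon-only ring. Compound 1 `Cc1cc(-c2ccc3[nH]c(=O)nc(-c4ccccc4)c3c2)ccn1` carries 2-methylpyridin-4-yl, compound 2 `O=c1nc(-c2ccccc2)c2cc(-c3cccnc3)ccc2[nH]1` carries pyridin-3-yl, and compound 3 `O=c1nc(-c2ccccc2)c2cc(-c3cncnc3)ccc2[nH]1` carries pyrimidin-5-yl. In an ADME assay on L6 cells (Rattus norvegicus) for cytotoxicity, read by fluorescence and resazurin assay, with a stated time of 72 h (a lower number here means that less compound is needed, a higher number that more compound is needed for the effect), compound 1 gives > 50000 nM, which is a limit of the assay rather than a number. In this assay compound 2 likewise gives only the limit > 50000 nM. In this assay compound 3 also stands at the limit > 50000 nM. The steps between them are accordingly unreadable: a step that the two limits leave unreadable from compound 1 to compound 2, a step that the two limits leave unreadable from compound 1 to compound 3 and a step that the two limits leave unreadable from compound 2 to compound 3. All three values sit at one point, (the limit of > 50000 nM in this assay, at which 3 of the 3 values shown sit).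

Compound 4 `Cn1nccc1-c1ccc2[nH]c(=O)nc(-c3ccccc3)c2c1` differs from compound 3 by 1-methyl-1H-pyrazol-5-yl in place of pyrimidin-5-yl on an aromatic carbon. Among the measured compounds shown here, none of the measured steps gives a readable size, so no direction can be drawn for this assay; the expectation rests on the three limits alone. Compound 4 is expected to remain at that limit, with an estimate of 60000 nM and a range from 30000 nM to 150000 nM. The expected step that the limit leaves unreadable from compound 3 to compound 4 is thus none beyond the scatter.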

Compound 4, half-maximal effective concentration: > 50000 nM
Compound 4 ended at the assay's limit; the forecaster's own chance of this, stated with the estimate: 85%; the middle value does not contradict the limit.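

In this assay compound 4 gives > 50000 nM, a limit and not a number, so the steps to compound 4 from compound 1, compound 2 and compound 3 cannot be read: the limit of > 50000 nM in this assay, at which 4 of the 4 values shown sit. The compounds shown leave open whether any aromatic group on the shared core gives a readable value in this assay.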